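Triazole-linked thioether series: sulfamoyl in place of chalcone arm

This account rests on a few compounds, and the source may have more. Where it says the series, first, only, none or still open, it means among the compounds named here.

Compound 1 `Clc1ccc(Cn2cc(CSc3nnc(-c4ccccc4)c(-c4ccccc4)n3)nn2)cc1` gives 14700 nM in a functional assay on PC-3 cells (Homo sapiens) for antiproliferative activity, read by MTT assay, with a stated time of 48 h; on this read-out higher numbers stand for weaker inhibition and lower numbers for stronger inhibition. In this assay compound 2 `COc1ccc(C(=O)/C=C/c2ccc(-n3cc(CSc4nnc(-c5ccccc5)c(-c5ccccc5)n4)nn3)cc2)cc1` gives a limit rather than a number, > 100000 nM. Compound 2 thus stands at the limit of > 100000 nM in this assay, at which 1 of the 2 values shown sits, with no measured value of its own. Compound 3 `NS(=O)(=O)c1ccc(-n2cc(CSc3nnc(-c4ccccc4)c(-c4ccccc4)n3)nn2)cc1` carries sulfamoyl in place of 2-((4-methoxyphenyl)carbonyl)ethenyl on an aromatic carbon. Within the data shown here, no measured step covers this change, so the expected step of an at least 3.3-fold lower number from compound 2 to compound 3 (0.52 log units; beyond the scatter) is taken to point toward stronger inhibition than the limit seen for compound 2, its size uncertain. For compound 3 the estimate in this assay is 30000 nM, within 8000 nM to 100000 nM.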

Compound 3, half-maximal inhibitory concentration: > 100000 nM
Compound 3 gave a limit, no number; the forecaster's own chance of this, stated with the estimate: 30%; middle value at least 3.3-fold (0.52 log units) from the limit.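

In this assay, 4-sulfamoylphenyl in place of 4-chlorobenzyl on the aromatic nitrogen gives an at least 6.8-fold higher number from compound 1 to compound 3 (0.83 log units; beyond the scatter), so this arm does not restore a measurable value. The change from compound 2 to compound 3 cannot be read, and sulfamoyl leaves the series where the 2-((4-methoxyphenyl)carbonyl)ethenyl arm left it: the limit of > 100000 nM in this assay, at which 2 of the 3 values shown sit.

From the compounds shown here alone, compound 3 changes both the linkage to the aromatic nitrogen and the group on the ring, so which change matters remains open. A 4-sulfamoylbenzyl or 4-chlorophenyl group there would separate the two.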